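A few compounds are considered here, and "the series" means these few. Any claim that something is new, unique, unknown or untested is made for them only; others in the source may bear on it.

Among the compounds with values here, in a functional assay on PC-3 cells (Homo sapiens) for cytotoxicity, read by MTT assay, with a stated time of 24 h (a higher number here means a weaker inhibitor, a lower number a stronger inhibitor), compound 1 (`O=C1/C(=C/c2ccccc2F)CN(Cc2cn(Cc3ccccc3F)nn2)C/C1=C\c1ccccc1F`) gives 19700 nM as the lowest of the numbers so far. Compound 2 (`Cc1ccc(/C=C2\CN(C(=S)SCc3cn(Cc4ccc(F)cc4)nn3)C/C(=C\c3ccc(C)cc3)C2=O)cc1`) stands higher with 45500 nM in the same test. Compound 3 (`Cc1ccc(/C=C2\CN(C(=S)SCc3cn(Cc4ccccc4F)nn3)C/C(=C\c3ccc(C)cc3)C2=O)cc1`) has no number and only a limit of > 80000 nM on record.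

Compound 4 (`O=C1/C(=C/c2ccccc2F)CN(Cc2cn(Cc3ccc(F)cc3)nn2)C/C1=C\c1ccccc1F`) keeps the core of compound 1 and changes one group (4-fluorophenyl in place of 2-fluorophenyl on a saturated chain carbon bound to an aromatic nitrogen) with 4-fluorophenyl in place of 2-fluorophenyl on a saturated chain carbon bound to an aromatic nitrogen.

Within the data shown here, one measured step bears on this exchange. It is an at least 1.7-fold higher number from compound 2 to compound 3 (0.24 log units; that floor lies within the scatter) and it runs the same exchange in the opposite direction. Compound 2 and compound 3 also carry other groups than compound 1, so the transfer to the core of compound 1 is uncertain. On these data alone, the floor of that step lies within the scatter and its true size is unknown. It therefore offers only a faint lean toward a lower number for the 4-fluorophenyl partner and gives no firm size.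

The expected step is a 1.3-fold lower number from compound 1 to compound 4 (0.12 log units; within the scatter) in this assay and it is not expected to clear the scatter. Compound 4 is therefore estimated at 15000 nM with an expected range from 5000 nM to 45000 nM on this evidence.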

Compound 4, half-maximal inhibitory concentration: 19400 nM
The estimate for compound 4 lay 1.3-fold (0.11 log units) below the measured number; measured number inside the range.
By their numbers in this assay, from the lowest: compounds 4 and 1 (each within the scatter of the next); then compound 2. At a limit, above all of these: compound 3.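

On the core of compound 1, the exchange of 2-fluorophenyl for 4-fluorophenyl on a saturated chain carbon bound to an aromatic nitrogen now has a size in this assay: it is a 1.0-fold lower number from compound 1 to compound 4 (0.01 log units; within the scatter) and gives this position its first step with a number at both ends. On this core, the two fluorobenzyl isomers therefore cannot be told apart in this test, which the earlier pair could not show. Compound 3 is recorded only as a limit, > 80000 nM, so the step on its core has no known size, and whether the exchange acts alike on the two cores cannot be settled: the same change on two cores in this assay, an at least 1.7-fold higher number (0.24 log units; that floor lies within the scatter) from compound 2 to compound 3 and a 1.0-fold higher number (0.01 log units; within the scatter) from compound 4 to compound 1; the limit leaves it open whether they differ.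

The compounds shown leave open whether a group other than these two fluorophenyl partners at this place, such as unsubstituted phenyl, 4-methoxyphenyl or a longer chain, would move the number beyond the scatter. On these data alone, compound 4 and compound 2 differ in more than one place, so it also remains open which of those differences bears on their values in this assay.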